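Anilino ring substitution in a thioether quinazoline series

The source may hold more compounds than are shown below. What is called first, only, known or untested is meant among the compounds shown, and "the series" means these compounds.

Compound 1 `FC(F)(F)c1ccc(CSc2nc(Nc3ccccc3)c3ccccc3n2)cc1` carries an unsubstituted anilino group on the shared core. Among the measured compounds shown here, in a functional assay on PC-3 cells (Homo sapiens) for cytotoxicity, read by MTT assay, with a stated time of 72 h (a lower number here means a stronger inhibitor, a higher number a weaker inhibitor), compound 1 gives 20000 nM, the highest of the three numbers measured so far, though its nearest neighbour compound 2 `COc1ccccc1Nc1nc(SCc2ccc(C(F)(F)F)cc2)nc2ccccc12` gives 14100 nM and compound 3 `FC(F)(F)c1ccc(CSc2nc(Nc3cccc(C(F)(F)F)c3)c3ccccc3n2)cc1` gives 12900 nM, both within the scatter of compound 1.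

Compound 4 `FC(F)(F)c1ccc(CSc2nc(Nc3ccc(Cl)cc3)c3ccccc3n2)cc1` differs from compound 1 by chloro in place of hydrogen on an aromatic carbon, on the anilino ring, the phenyl becoming 4-chlorophenyl. For the measured compounds named here, two measured steps bear on this: a 1.4-fold lower number from compound 1 to compound 2 (0.15 log units; within the scatter) and a 1.6-fold lower number from compound 1 to compound 3 (0.19 log units; within the scatter), each a substituent entering an aromatic carbon of the same ring in place of hydrogen, each within the scatter. The third step, a 1.1-fold lower number from compound 2 to compound 3 (0.04 log units; within the scatter), also stays within the scatter. Substitution on this ring has so far moved nothing beyond the noise, so no step beyond the scatter is expected for chloro either.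

Compound 4 is therefore estimated at 15000 nM, range 7000 nM to 32000 nM, which means an expected step of a 1.3-fold lower number from compound 1 to compound 4 (0.12 log units; within the scatter).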

Compound 4, half-maximal inhibitory concentration: 7110 nM
Compound 4: the middle estimate sits 2.1-fold (0.32 log units) above what was measured, and the stated range covers the measured number.
By their numbers in this assay, from the lowest: compounds 4, 3, 2 and 1 (each within the scatter of the next, the first and the last beyond it).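

Chloro on the anilino ring, giving 4-chlorophenyl, is the first change at this ring to step beyond the scatter in this assay (a 2.8-fold lower number from compound 1 to compound 4 (0.45 log units; beyond the scatter)), whereas the methoxy and trifluoromethyl changes stayed within it. The gain is limited to the comparison with the unsubstituted phenyl: the steps to the other two substituted rings (a 1.8-fold lower number from compound 3 to compound 4 (0.26 log units; within the scatter); a 2.0-fold lower number from compound 2 to compound 4 (0.30 log units; within the scatter)) remain within the scatter, so 4-chlorophenyl is not set apart from 3-(trifluoromethyl)phenyl or 2-methoxyphenyl. No supporting data explain the step.

Each of the three substituted rings differs in both the group and its place on the ring, so the contribution of place remains unresolved. Also open, as far as these compounds go, is whether bromo, hydroxyl or an amine in the same place, para to a large group, would match or extend the chloro step.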